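The compounds below may be only part of what the source reports. "The series", "measured", "known", "first", "only" and "open" are said of these compounds alone.

Measured in a functional assay on HepG2 cells (Homo sapiens) for cytotoxicity, read by MTT assay, with a stated time of 48 h; on this read-out higher numbers stand for weaker inhibition and lower numbers for stronger inhibition:
- compound 1 `CC1=NN(C(=O)c2ccc(C)cc2)C(c2ccccc2O)C1`: 11300 nM
- compound 2 `CCC(=O)N1N=C(C)CC1c1cc(Br)cc(Br)c1O`: 41400 nM
- compound 3 `CC1=NN(C(=O)CN2CCCC2)C(c2ccccc2O)C1`: 5540 nM

Of these three, compound 3 has the lowest number, 5540 nM. Compound 4 `CC1=NN(C(=O)CN2CCN(C)CC2)C(c2ccccc2O)C1` has 4-methylpiperazin-1-yl in place of pyrrolidin-1-yl on a saturated chain carbon bound to a carbonyl carbon. Among the measured compounds shown here, only one measured step bears on this place: a 2.0-fold lower number from compound 1 to compound 3 (0.31 log units; beyond the scatter), a modest change that exchanged 4-methylphenyl for (pyrrolidin-1-yl)methyl. For the measured compounds named here, no measured step exchanges one saturated ring for another, so the data give no direction, and no step beyond the scatter is expected in this assay. The estimated step is a 1.2-fold higher number from compound 3 to compound 4 (0.07 log units; within the scatter). Compound 4 is expected at about 6500 nM, within an estimated range of 2800 nM to 15000 nM.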

Compound 4, half-maximal inhibitory concentration: "not active" (no number reported)
For compound 4 the study gives words and no number; no gap can be computed for the estimate.
By their numbers in this assay, from the lowest: compound 3; then compound 1; then compound 2.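

Among the compounds shown here, compound 4 is reported in this assay only in words, as "not active", so no step from compound 3 to compound 4 can be read. No measurement shown accounts for this result. The compounds shown leave open how far 4-methylpiperazin-1-yl shifts the number relative to pyrrolidin-1-yl.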